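The source may hold more compounds than are shown below. What is called first, only, known or untested is meant among the compounds shown, and "the series" means these compounds.

Measured compounds:
Compound 1, `CCNc1ncc2c(n1)N(C)CCN(c1cccc(-c3nnc(C)o3)c1)C2=O`, gives 2970 nM.
Compound 2, `CCN(C)c1ncc2c(n1)N(C)CCN(c1cccc(-c3nnc(C)o3)c1)C2=O`, gives "not determined" (no result reported).

The account concerns the step from compound 2 to compound 3. In an assay on membranes from HEK293 cells for displacement of a labelled ligand from Voltage-dependent calcium channel subunit alpha-2/delta-2 (Homo sapiens), read by scintillation counting, with a stated time of 60 min (a lower number here means a stronger inhibitor, a higher number a weaker inhibitor), compound 2 has no single number: the record shows "not determined" (no result reported), so its standing cannot be placed on the scale at all. The only measured anchor in this assay is compound 1, which gives 2970 nM, a weak result.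

Compound 3, `CNc1ncc2c(n1)N(C)CCN(c1cccc(-c3nnc(C)o3)c1)C2=O`, differs from compound 2 by hydrogen in place of ethyl on a nitrogen on an aromatic ring; put another way, the ethyl(methyl)amino group of compound 2 becomes the methylamino group of compound 3. For the measured compounds named here, no step between measured compounds is available to calibrate this change, and the starting point itself lacks a value, so nothing in the data says how large the step in this assay should be or in which direction it runs. The expectation therefore rests on the weak result of compound 1 alone, read as the general level of this series.

On that basis compound 3 is estimated at 3000 nM, within a broad range from 700 nM to 13000 nM.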

Compound 3, inhibition constant: > 10000 nM
Compound 3 was reported as a limit; the forecaster's own chance of this, stated with the estimate: 25%; middle value at least 3.3-fold (0.52 log units) from the limit.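

In this assay, for the compounds shown here, the first readable comparison is an at least 3.3-fold higher number from compound 1 to compound 3 (0.52 log units; beyond the scatter), where hydrogen takes the place of methyl on a saturated chain carbon bound to a nitrogen on an aromatic ring. The ethylamino group of compound 1 thus gives way to the methylamino group of compound 3, and this small trim weakens the result beyond the scatter, showing that binding is sensitive to the substituent on this nitrogen even though compound 1 was already weak. Compound 3 stands at a limit of the assay and not at a number, so the step gives only a minimum size: the limit of > 10000 nM in this assay, at which 1 of the 3 values shown sits.

Going by these compounds, the step from compound 2 to compound 3 cannot be read, and the effect of the ethyl(methyl)amino group therefore remains unknown. The compounds shown also leave open whether a longer chain such as propyl, a branched chain such as isopropyl, or an unsubstituted amine at this nitrogen would move the result in either direction, and how far below the level of compound 1 any such change could go.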